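A few compounds are considered here, and "the series" means these few. Any claim that something is new, unique, unknown or untested is made for them only; others in the source may bear on it.

Measured so far:
- compound 1 `CN1C[C@H](C(=O)Nc2ccc(F)c(F)c2)[C@@H](c2ccc(/C=C/C(=O)Nc3ccccc3N)cc2)C1` gives 53 mL/min/kg
- compound 2 `CC(C)N1C[C@H](C(=O)Nc2ccc(Cl)cc2)[C@@H](c2ccc(/C=C/C(=O)Nc3ccccc3N)cc2)C1` gives 86 mL/min/kg

In an in vivo ADME assay on the whole organism (strain BALB/C) for pharmacokinetics, with Mus musculus as the target, read by LC-MS (a higher number here means faster removal of the compound, a lower number slower removal), compound 2 stands at 86 mL/min/kg and compound 1 at 53 mL/min/kg as a pair within the scatter, so these numbers do not rank the two. Compound 3 `CC(C)(C)N1C[C@H](C(=O)Nc2ccc(Cl)cc2)[C@@H](c2ccc(/C=C/C(=O)Nc3ccccc3N)cc2)C1` departs from compound 2 in one place (methyl in place of hydrogen on a saturated chain carbon bound to an amine nitrogen in a ring and two saturated chain carbons) with methyl in place of hydrogen on a saturated chain carbon bound to an amine nitrogen in a ring and two saturated chain carbons, which reads as isopropyl to tert-butyl. Among the measured compounds shown here, the two measured compounds differ in more than one place, so no measured step speaks to this change. No step beyond the scatter is expected, and the expectation starts from compound 2 at 86 mL/min/kg as the closest measured structure. The expected change is a 1.1-fold lower number from compound 2 to compound 3 (0.03 log units; within the scatter) and it has no firm direction. For compound 3 the estimate is 80 mL/min/kg with an expected range from 45 mL/min/kg to 140 mL/min/kg in these notes.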

Compound 3, clearance: 60 mL/min/kg
Compound 3: middle estimate off by 1.3-fold (0.12 log units), on the high side, and the stated range covers the measured number.
By their numbers in this assay, from the lowest: compounds 1, 3 and 2 (each within the scatter of the next).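

Among the compounds shown here, this is the first step that changes a single place, and in this assay it reads a 1.4-fold lower number from compound 2 to compound 3 (0.16 log units; within the scatter). Methyl in place of hydrogen on a saturated chain carbon bound to an amine nitrogen in a ring and two saturated chain carbons, read as isopropyl to tert-butyl, therefore gives no separable change in this read-out for the pair with the chlorine-bearing anilide, something the earlier pair could not show since its members differ in more than one place. No measurement on hand accounts for this outcome, so the step stands as an observation only.

The compounds shown leave open whether other groups in this place, such as a cyclopropyl ring, a longer chain like n-butyl or a chain carrying a carboxylic acid, would stay within the scatter of compound 2 or move beyond it. For the compounds shown here, the effect of the substituents on the anilide ring also remains unread, as compound 1 differs from compound 2 and compound 3 in more than one place and no single-place step connects it to either.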